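The source may report more compounds than this note shows. Statements on the series, on what has been measured and on what is new or still open speak of the compounds shown alone.

Of the compounds shown here, three have so far been measured in an assay for inhibition of RAC-alpha serine/threonine-protein kinase (Homo sapiens), read by HTRF, with a stated time of 1 h; on this read-out higher numbers stand for weaker inhibition and lower numbers for stronger inhibition. Compound 1 `Cn1ncc(Cl)c1-c1cc(C(=O)NC2CNCCC2c2ccc(C(F)(F)F)cc2)oc1Cl` gives 7.2 nM, compound 2 `Cn1ncc(Cl)c1-c1cc(C(=O)NC2CNCC2c2ccc(C(F)(F)F)cc2)oc1Cl` gives 538 nM, and compound 3 `Cn1ncc(Cl)c1-c1cc(C(=O)N[C@@H]2CN[C@H](CCn3cncn3)C[C@H]2c2ccc(Cl)c(Cl)c2)oc1Cl` gives 4.47 nM. Compound 3 thus holds the lowest number of the three; compound 1 sits within the usual scatter of it, while compound 2 lies far beyond it. No two of these compounds differ in only one place, so no single measured step is available as a guide. Compound 4 `Cn1ncc(Cl)c1-c1cc(C(=O)N[C@@H]2CN[C@H](CC(=O)NCC(O)CO)C[C@H]2c2ccc(Cl)c(Cl)c2)oc1Cl` differs from compound 3 in one place: (2,3-dihydroxypropyl)carbamoyl in place of (1H-1,2,4-triazol-1-yl)methyl on a saturated chain carbon bound to a saturated ring carbon. Among the measured compounds shown here, with no comparable step measured, the expectation is a step of a 1.8-fold higher number from compound 3 to compound 4 (0.25 log units; within the scatter), that is, nothing beyond the scatter. Compound 4 is therefore estimated at 8 nM, with a range from 2 nM to 30 nM.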

Compound 4, half-maximal inhibitory concentration: 3.13 nM
The estimate for compound 4 lay 2.6-fold (0.41 log units) above the measured number, and the stated range covers the measured number.
By their numbers in this assay, from the lowest: compounds 4, 3 and 1 (each within the scatter of the next, the first and the last beyond it); then compound 2.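

In this assay, putting (2,3-dihydroxypropyl)carbamoyl in place of (1H-1,2,4-triazol-1-yl)methyl on a saturated chain carbon bound to a saturated ring carbon gives a 1.4-fold lower number from compound 3 to compound 4 (0.15 log units; within the scatter). This place therefore accepts an open chain with hydrogen-bond donors as well as an aromatic ring without donors, and the two compounds read alike. Nothing measured here explains this tolerance. Going by these compounds, whether an amine or a carboxylic acid in the same place would also read alike remains open. So does whether a longer chain would.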